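The source may report more compounds than this note shows. Statements on the series, on what has been measured and on what is new or still open speak of the compounds shown alone.

Measured in an assay on isolated protein for displacement of a labelled ligand from metabotropic glutamate receptor 5 (Homo sapiens), with a stated time of 60 min, tested at 1 uM; a lower number here means less inhibition, a higher number more inhibition at the concentration tested (going by the name of the read-out):
compound 1 `Cc1ccc(S(=O)(=O)c2cnc3cc(Cl)ccc3c2N2CCC(C)CC2)cc1F`, 85%
compound 2 `O=S(=O)(c1ccc(F)cc1)c1cnc2cc(Cl)ccc2c1N1CCC(CO)CC1`, 75%
compound 3 `CC1CCN(c2c(S(=O)(=O)c3ccc(F)cc3)cnc3cc(F)ccc23)CC1`, 74.5%

Compound 3 gives the lowest of the three numbers in this assay; compound 2 sits nearest, within the scatter, while compound 1 lies beyond it. Compound 4 `CC1CCN(c2c(S(=O)(=O)c3ccc(F)cc3)cnc3cc(Cl)ccc23)CC1` differs from compound 3 in one place: chloro in place of fluoro on an aromatic carbon. Among the measured compounds shown here, no measured pair shows this change on its own. Compound 1 and compound 2 each carry chloro on an aromatic carbon of the fused system and give the higher numbers, but each also differs from compound 3 elsewhere, so no size of step can be read from them. A small upward step, not beyond the scatter, is expected: a number 5.5 percentage points higher from compound 3 to compound 4 (within the scatter). Compound 4 is estimated at 80%, between 68% and 90%.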

Compound 4, a percentage reported as inhibition, at one concentration (the size of the read-out at that concentration, not a potency): 91%
Compound 4: the middle estimate sits 11 percentage points below what was measured, outside the stated range (above it).
By their numbers in this assay, from the lowest: compounds 3, 2, 1 and 4 (each within the scatter of the next, the first and the last beyond it).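

In this assay, among the compounds shown here, chloro in place of fluoro on this aromatic carbon gives a number 16.5 percentage points higher from compound 3 to compound 4 (beyond the scatter) as the first reading of this change alone, with the rest of the molecule held constant. With chloro on that carbon, hydrogen in place of hydroxy on the saturated chain carbon gives a number 16 percentage points higher from compound 2 to compound 4 (beyond the scatter) and 4-fluorophenyl in place of 3-fluoro-4-methylphenyl on the sulfonyl sulfur gives a number 6 percentage points higher from compound 1 to compound 4 (within the scatter) and so stays within the scatter. No measured evidence bears on the origin of these steps.

Going by these compounds, how bromo, methoxy or nitrile on the same aromatic carbon would compare remains open. Also open, on these data alone, is whether the chloro for fluoro step holds with a hydroxymethyl group or 3-fluoro-4-methylphenyl elsewhere in the molecule.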